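The source may hold more compounds than are shown below. What is called first, only, known or untested is meant among the compounds shown, and "the series" means these compounds.

Within the data shown here, in a functional assay on L1210 cells (Mus musculus) for inhibition (on this read-out higher numbers stand for weaker inhibition and lower numbers for stronger inhibition), compound 1 (`CCCC(=O)OCCNc1ncnc2c1C(=O)C(OC)=CC2=O`) gives 2660 nM and compound 2 (`CCN(CC)CCCNc1ncnc2c1C(=O)C(OC)=CC2=O`) gives 1240 nM, which makes compound 2 the lower of the two numbers measured so far. Compound 3 (`COC1=CC(=O)c2ncnc(NCCN(C)C)c2C1=O`) keeps the shared core and differs from compound 2 in one place: dimethylamino in place of (diethylamino)methyl on a saturated chain carbon, two bonds along the chain from a nitrogen on an aromatic ring. The change puts dimethylamino in place of (diethylamino)methyl on a saturated chain carbon, two bonds along the chain from a nitrogen on an aromatic ring. Among the measured compounds shown here, only one measured step bears on it, and only indirectly: a 2.1-fold lower number from compound 1 to compound 2 (0.33 log units; beyond the scatter), a modest move beyond the scatter that involved a different pair of groups at that place. With that single step as a guide, no firm direction can be set for the new change, and a shift no larger than that modest one is expected. The estimated step is a 1.1-fold higher number from compound 2 to compound 3 (0.05 log units; within the scatter), which is expected to stay within the scatter. For compound 3 the expected value is 1400 nM, with an estimated range of 600 nM to 3300 nM.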

Compound 3, half-maximal inhibitory concentration: 1140 nM
Estimate against measurement, compound 3: 1.2-fold (0.09 log units) above; the range from low to high includes it.
By their numbers in this assay, from the lowest: compounds 3 and 2 (each within the scatter of the next); then compound 1.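

In this assay, dimethylamino in place of (diethylamino)methyl on a saturated chain carbon, two bonds along the chain from a nitrogen on an aromatic ring, gives a 1.1-fold lower number from compound 2 to compound 3 (0.04 log units; within the scatter), so going from 6 heavy atoms in the group to 3 does not move the read-out beyond the scatter. Replacing (propylcarbonyl)oxy with dimethylamino at this place gives a 2.3-fold lower number from compound 1 to compound 3 (0.37 log units; beyond the scatter), so both amine-bearing compounds now stand apart from the ester compound 1 by a modest margin. No measurement available here accounts for either result.

The compounds shown leave open whether a cyclic amine such as piperidine or morpholine would fit this pattern. They also leave open how a hydroxyl group or a plain alkyl chain would read at this place.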